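A Pyrrole in Place of a Five-Membered Ring on the Amide

The compounds below may be only part of what the source reports. "The series", "measured", "known", "first", "only" and "open" are said of these compounds alone.

Measured so far:
compound 1, `O=C(Nc1ccc(C(F)(F)F)cc1)NC1CCN(C(=O)C2=COCC2)CC1`, 2.3 ug/mL
compound 2, `O=C(Nc1ccc(OC(F)(F)F)cc1)NC1CCN(C(=O)C2=COCC2)CC1`, 11 ug/mL
compound 3, `O=C(Nc1ccc(OC(F)(F)F)c(F)c1)NC1CCN(C(=O)C2CCOCC2)CC1`, 77 ug/mL

In a physicochemical assay for solubility, read by mass spectrometry, in phosphate buffer, with a stated time of 24 h, at pH 7.4 (a lower number here means a less soluble compound, a higher number a more soluble compound), compound 1 gives the lowest of the three numbers. Among the measured compounds shown here, its nearest neighbour is compound 2, and the single change between them, trifluoromethoxy in place of trifluoromethyl on an aromatic carbon, brings a 4.8-fold higher number from compound 1 to compound 2 (0.68 log units; beyond the scatter). For the measured compounds named here, compound 3 differs from compound 1 in more than one place, so no single step connects them; its value simply stands far above that of compound 1.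

Compound 4, `O=C(Nc1ccc(C(F)(F)F)cc1)NC1CCN(C(=O)c2cc[nH]c2)CC1`, has not yet been measured. It differs from compound 1 in one place: a group of 5 heavy atoms (4 carbon, 1 nitrogen; one five-membered aromatic ring with 1 hetero atom) in place of a group of 5 heavy atoms (4 carbon, 1 oxygen; one five-membered non-aromatic ring with 1 hetero atom), on a carbonyl carbon. Going by the values given here, no measured step alters this part of the shared core; the one step recorded from compound 1 concerns the substituent on the aromatic ring, not the group on the carbonyl carbon. The present data therefore offer no direct guide for this change.

With nothing to lean on, the expectation is that compound 4 stays near compound 1, a step of a 1.3-fold higher number from compound 1 to compound 4 (0.12 log units; within the scatter) that is expected to remain within the scatter. The estimate for compound 4 in this assay is 3 ug/mL, with a range from 0.8 ug/mL to 12 ug/mL.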

Compound 4, solubility: 1.8 ug/mL
Beside the measured number, compound 4's estimate is 1.7-fold (0.22 log units) above it; measured number inside the range.
By their numbers in this assay, from the lowest: compounds 4 and 1 (each within the scatter of the next); then compound 2; then compound 3.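

Among the compounds shown here, this is the first reading at the group on the carbonyl carbon whose other neighbour is the amide-type nitrogen in a ring. In this assay, placing 1H-pyrrol-3-yl there gives a 1.3-fold lower number from compound 1 to compound 4 (0.11 log units; within the scatter), so the two compounds cannot be told apart in this measurement, even though a non-aromatic ring with an oxygen has given way to an aromatic ring with a nitrogen and the entering group brings 1 hydrogen-bond donor where the leaving group had none. Nothing on hand speaks to why the two groups read alike.

This single pair, both members carrying trifluoromethyl on the aromatic ring, leaves open whether 1H-pyrrol-3-yl would also read like the present group in compound 2, where trifluoromethoxy takes that place. It also leaves open whether a different kind of group on this carbonyl carbon, such as a ring bearing an amine or a carboxylic acid, or an open chain such as ethyl, would move the number beyond the scatter.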